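The compounds below may be only part of what the source reports. "The series", "measured", "known", "first", "only" and "open" are said of these compounds alone.

Series notes in an assay on cells for antagonist activity at transient receptor potential cation channel subfamily V member 1 (Homo sapiens), read by FLIPR and calcium flux, with a stated time of 6 min; a higher number here means a weaker inhibitor, a lower number a stronger inhibitor. Compound 1 `CCCOc1nc(C(C)(C)C)ccc1CNC(=O)C(C)c1ccc(NS(C)(=O)=O)c(F)c1` gives 1.7 nM. Within the data shown here, compound 2 `CC(C)Oc1nc(C(C)(C)C)ccc1CNC(=O)C(C)c1ccc(NS(C)(=O)=O)c(F)c1` gives 2.3 nM, the highest of the three numbers measured so far. Compound 3 `CC(C)CCOc1nc(C(C)(C)C)ccc1CNC(=O)C(C)c1ccc(NS(C)(=O)=O)c(F)c1` gives 0.8 nM. The step of a 1.4-fold higher number from compound 1 to compound 2 (0.13 log units; within the scatter) stays within the scatter, whereas a 2.9-fold lower number from compound 2 to compound 3 (0.46 log units; beyond the scatter) and a 2.1-fold lower number from compound 1 to compound 3 (0.33 log units; beyond the scatter) are modest but beyond it, so within this set the isopentyl group on the aromatic oxygen goes with the lowest number.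

Compound 4 `CC(C(=O)NCc1ccc(C(C)(C)C)nc1SCc1ccccc1)c1ccc(NS(C)(=O)=O)c(F)c1` is not yet measured in this assay. It differs from compound 2 as follows: benzylsulfanyl in place of isopropoxy on an aromatic carbon. Among the measured compounds shown here, the steps that bear on this are the two starting from compound 2, a 1.4-fold higher number from compound 1 to compound 2 (0.13 log units; within the scatter) and a 2.9-fold lower number from compound 2 to compound 3 (0.46 log units; beyond the scatter): changes at this position have so far moved the number little or modestly downward. For the measured compounds named here, no measured compound carries a sulfur or a benzyl group at this position, so the expectation rests on that trend alone. A modest lower number is expected, a 1.6-fold lower number from compound 2 to compound 4 (0.22 log units; within the scatter), with wide uncertainty. Compound 4 is estimated at 1.4 nM, in the range 0.4 nM to 5 nM.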

Compound 4, inhibition constant: 4 nM
Compound 4: middle estimate off by 2.9-fold (0.46 log units), on the low side; measured number inside the range.
By their numbers in this assay, from the lowest: compound 3; then compounds 1, 2 and 4 (each within the scatter of the next, the first and the last beyond it).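

At the aromatic carbon next to the ring nitrogen, benzylsulfanyl is tolerated in this assay: a 1.7-fold higher number from compound 2 to compound 4 (0.24 log units; within the scatter) stays close to the isopropoxy compound even though sulfur and an aromatic ring both enter here. The longer isopentyloxy group does not set a trend that carries over to benzylsulfanyl, since a 5.0-fold higher number from compound 3 to compound 4 (0.70 log units; beyond the scatter) is modest but beyond the scatter, as is a 2.4-fold higher number from compound 1 to compound 4 (0.37 log units; beyond the scatter) against the propoxy compound. Nothing available accounts for these differences, and the change alters both the linking atom and the group beyond it.

The compounds shown leave open whether the sulfur or the benzyl group goes with the higher numbers, a question that benzyloxy and propylsulfanyl at this position would separate. On these data alone, how an amine at this position would compare also remains open.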